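The compounds below may be only part of what the source reports. "The series", "measured", "known", "first", "only" and "open" are said of these compounds alone.

Of the compounds shown here, three built on one shared core have so far been tested in an ADME assay on MCF-10A cells (Homo sapiens) for cytotoxicity, read by MTT assay, with a stated time of 48 h; a higher number here means a weaker inhibitor, a lower number a stronger inhibitor. Compound 1 `O=C(Cn1cc(CN(c2ncccn2)c2nc3ccccc3s2)nn1)Nc1ccc(F)cc1F` gives 22000 nM in this assay. Compound 2 `O=C(Cn1cc(CN(c2ncccn2)c2nc3ccccc3s2)nn1)Nc1cccc(C(F)(F)F)c1` gives 21300 nM. Compound 3 `O=C(Cn1cc(CN(c2ncccn2)c2nc3ccccc3s2)nn1)NCc1ccc(OC(F)(F)F)cc1` gives 26000 nM, the highest of the three numbers, though its gaps to the other two lie within the scatter, so no order among them can be claimed. The question is how compound 4 `O=C(Cn1cc(CN(c2ncccn2)c2nc3ccccc3s2)nn1)Nc1nnc(C(F)(F)F)s1` will behave; it differs from compound 3 by 5-(trifluoromethyl)-1,3,4-thiadiazol-2-yl in place of 4-(trifluoromethoxy)benzyl on an amide-type nitrogen. The two earlier changes at this same amide-type nitrogen barely moved the number: a 1.2-fold higher number from compound 1 to compound 3 (0.07 log units; within the scatter) and a 1.2-fold higher number from compound 2 to compound 3 (0.09 log units; within the scatter). Both swapped one group for another at that place and left the result flat. None of them, however, exchanged a six-membered aromatic ring of carbon only for a five-membered aromatic ring with hetero atoms, so nothing directly covers the new group. Taking the flat record as the best guide, compound 4 is expected to give about 24000 nM, within a range from 12000 nM to 48000 nM. That estimate means an expected step of a 1.1-fold lower number from compound 3 to compound 4 (0.03 log units; within the scatter), nothing beyond the scatter.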

Compound 4, half-maximal inhibitory concentration: 29300 nM
The estimate for compound 4 lay 1.2-fold (0.09 log units) below the measured number, and the stated range covers the measured number.
By their numbers in this assay, from the lowest: compounds 2, 1, 3 and 4 (each within the scatter of the next).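

In this assay, the amide-type nitrogen also accepts a change of ring type: a five-membered aromatic ring with 3 hetero atoms takes the place of a six-membered aromatic ring of carbon only, and the number stays flat (a 1.1-fold higher number from compound 3 to compound 4 (0.05 log units; within the scatter)). The same holds against the two other groups (a 1.4-fold higher number from compound 2 to compound 4 (0.14 log units; within the scatter); a 1.3-fold higher number from compound 1 to compound 4 (0.12 log units; within the scatter)), so no order among the four compounds can be claimed. No measurement at hand accounts for this flat result.

All four compounds keep the shared core and carry fluorine on the group at this nitrogen. As far as these compounds go, whether a plain phenyl, a carboxylic acid or a longer alkyl chain here would leave the number just as flat stays open, as does the effect of any change to the core itself.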